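A few compounds are considered here, and "the series" means these few. Any claim that something is new, unique, unknown or untested is made for them only; others in the source may bear on it.

Compounds measured so far, in a functional assay on PC-3 cells (Homo sapiens) for cytotoxicity, read by MTT assay, with a stated time of 72 h; on this read-out higher numbers stand for weaker inhibition and lower numbers for stronger inhibition:

Compound 1, `FC(F)(F)c1ccc(CSc2nc(N3CCCCC3)c3ccccc3n2)cc1` — 25500 nM
Compound 2, `FC(F)(F)c1ccc(CSc2nc(Nc3ccccc3C(F)(F)F)c3ccccc3n2)cc1` — 34800 nM
Compound 3, `FC(F)(F)c1ccc(CSc2nc(Nc3ccc(Cl)cc3)c3ccccc3n2)cc1` — 7110 nM

Compound 3 stands lowest of the three numbers in this assay. Its step from compound 1 reads a 3.6-fold lower number from compound 1 to compound 3 (0.55 log units; beyond the scatter), and from compound 2 it reads a 4.9-fold lower number from compound 2 to compound 3 (0.69 log units; beyond the scatter); both lie beyond the scatter, while compound 1 and compound 2 sit close to each other at a 1.4-fold higher number from compound 1 to compound 2 (0.14 log units; within the scatter).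

Compound 4, `COc1cc(Nc2nc(SCc3ccc(C(F)(F)F)cc3)nc3ccccc23)cc(OC)c1`, is the next point. It differs from compound 3 in one place: 3,5-dimethoxyphenyl in place of 4-chlorophenyl on a nitrogen on an aromatic ring. Within the data shown here, the step that bears most directly on this is the one from compound 2 to compound 3, where exchanging one aryl group for another on that same nitrogen shifted the number by a 4.9-fold lower number from compound 2 to compound 3 (0.69 log units; beyond the scatter). The step from compound 1 to compound 3 shows that the group on this position moves the number by a similar, modest amount. Among the measured compounds shown here, nothing among the measured compounds speaks to a dimethoxyphenyl in particular, so the direction is open; a modest step in either direction, or none beyond the scatter, is the expectation.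

Taking this together, compound 4 is estimated to come in at 9000 nM, with a range of 3000 nM to 30000 nM, which would mean an expected step of a 1.3-fold higher number from compound 3 to compound 4 (0.10 log units; within the scatter).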

Compound 4, half-maximal inhibitory concentration: > 50000 nM
Compound 4 gave a limit, no number; the forecaster's own chance of this, stated with the estimate: 10%; middle value at least 5.5-fold (0.74 log units) from the limit.
By their numbers in this assay, from the lowest: compound 3; then compounds 1 and 2 (each within the scatter of the next). At a limit, above all of these: compound 4.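

In this assay compound 4 gave a limit and no number: the limit of > 50000 nM in this assay, at which 1 of the 4 values shown sits.

Placing 3,5-dimethoxyphenyl in place of 4-chlorophenyl on the same nitrogen gives an at least 7.0-fold higher number from compound 3 to compound 4 (0.84 log units; beyond the scatter), which shows that a change of the aryl group here can take the read-out well away from the lowest number in the set, even though the rest of the structure stays the same. Against the other two compounds, the floors are an at least 1.4-fold higher number from compound 2 to compound 4 (0.15 log units; that floor lies within the scatter) and an at least 1.9-fold higher number from compound 1 to compound 4 (0.29 log units; that floor lies within the scatter), so these floors do not by themselves separate compound 4 from compound 2 or compound 1, and only the step from compound 3 is firmly beyond the scatter.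

The compounds shown leave open whether a single methoxy group, as in 4-methoxyphenyl, or a 3,5-dichlorophenyl on this nitrogen would read close to compound 3 or go the way of compound 4. With the remainder of the structure shared by all four compounds, they also say nothing about how morpholin-4-yl in place of piperidin-1-yl would read, or how far past its limit compound 4 lies.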